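A few compounds are considered here, and "the series" means these few. Any claim that something is new, unique, unknown or untested is made for them only; others in the source may bear on it.

Measured so far:
- compound 1, `CC(C)(C)C(=O)N1CCN(c2nc(=O)c3cc(C(F)(F)F)cc([N+](=O)[O-])c3s2)CC1`: > 125000 nM
- compound 2, `CCCCC(=O)N1CCN(c2nc(=O)c3cc(C(F)(F)F)cc([N+](=O)[O-])c3s2)CC1`: > 125000 nM

In an ADME assay on Vero cells (Chlorocebus sabaeus) for cytotoxicity, read by MTT assay, with a stated time of 72 h (a lower number here means that less compound is tolerated, a higher number that more compound is tolerated), compound 1 gives > 125000 nM, which is a limit of the assay rather than a number. Compound 2 gives > 125000 nM in this assay, again a limit. For the measured compounds named here, the one measured step, a step that the two limits leave unreadable from compound 1 to compound 2, therefore cannot be read, and the only evidence available is the limit of > 125000 nM in this assay, at which 2 of the 2 values shown sit, so compound 2 stands at that limit with no number of its own.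

The next compound, compound 3, `O=C(c1ccc(F)cc1)N1CCN(c2nc(=O)c3cc(C(F)(F)F)cc([N+](=O)[O-])c3s2)CC1`, differs from compound 2 by 4-fluorophenyl in place of butyl on a carbonyl carbon. Going by the values given here, no measured step speaks to this change, and the single step that is known, a step that the two limits leave unreadable from compound 1 to compound 2, is itself unreadable. Nothing on hand supports a shift in either direction beyond the scatter, and both measured values sit where the limit of > 125000 nM in this assay, at which 2 of the 2 values shown sit, lies. Compound 3 is therefore expected to give 125000 nM in this assay, within 50000 nM to 300000 nM, most likely reported again as a limit. The step that this expectation means, a number no higher from compound 2 to compound 3 (the limit leaves the size open), is estimated as none beyond the scatter.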

Compound 3, half-maximal cytotoxic concentration: > 125000 nM
Compound 3 gave a limit, no number; the forecaster's own chance of this, stated with the estimate: 70%; the middle value sits exactly at the limit.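

In this assay compound 3 gives > 125000 nM, which is a limit of the assay and not a number. The steps among compound 1, compound 2 and compound 3 therefore cannot be read: the limit of > 125000 nM in this assay, at which 3 of the 3 values shown sit.

As far as these compounds go, whether tert-butyl, butyl and 4-fluorophenyl on the carbonyl carbon differ at all in tolerated concentration, and where the half-maximal cytotoxic concentration of each compound lies, stays open.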